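A few compounds are considered here, and "the series" means these few. Any claim that something is new, unique, unknown or untested is made for them only; others in the source may bear on it.

Compound 1 `O=C1c2ccc(O)c(O)c2C(=O)N1Cc1ccccc1`: "not determined" (no result reported)
Compound 2 `O=C1c2ccc(O)c(O)c2C(=O)N1Cc1ccc(F)cc1`: "not determined" (no result reported)
Compound 3 `O=C1c2ccc(O)c(O)c2C(=O)N1Cc1cccc(Cl)c1`: 13300 nM

For the measured compounds named here, in an ADME assay on HOS cells (Homo sapiens) for cytotoxicity (a higher number here means a weaker inhibitor, a lower number a stronger inhibitor), compound 3 stands at 13300 nM and is the only compound with a number. Compound 1 and compound 2 have no result, which leaves nothing to rank compound 3 against. Compound 4 `O=C1c2ccc(O)c(O)c2C(=O)N1Cc1cccc(Br)c1` keeps the shared core and has bromo in place of chloro on an aromatic carbon of a six-membered aromatic ring of carbon only. Going by the values given here, no measured step shows what this swap does. In this assay no step beyond the scatter is expected, and no direction is favoured. The estimated step is a 1.1-fold lower number from compound 3 to compound 4 (0.04 log units; within the scatter) and remains within that scatter. For compound 4 the expected value is 12000 nM with an estimated range from 6000 nM to 25000 nM in this assay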

Compound 4, half-maximal inhibitory concentration: 11400 nM
Compound 4: middle estimate off by 1.1-fold (0.02 log units), on the high side, within the range that was stated.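

In this assay, for the compounds shown here, the 3-chlorophenyl to 3-bromophenyl swap gives the first readable step, a 1.2-fold lower number from compound 3 to compound 4 (0.07 log units; within the scatter), so chloro and bromo at this place on the aromatic ring are not told apart. No available evidence bears on this result. Steps involving compound 1 and compound 2 cannot be read. Still open, on these data alone, is whether a group of another kind at this place, such as an amine, a carboxylic acid or a longer chain, would give a step beyond the scatter.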